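Cyclopentyl Replacing Pyridinyl on a Fluorinated Core

The compounds below may be only part of what the source reports. "The series", "measured", "known", "first", "only" and "open" are said of these compounds alone.

Compound 1, `C#CCn1cc(C(=O)NC(CC(=O)Nc2ccccn2)c2ccccc2)c(=O)c2ccc(Cl)nc21`, gives > 10000 nM, a limit of the assay and not a number.
Compound 2, `C#CCn1cc(C(=O)NC(CC(=O)NC2CCCC2)c2ccccc2)c(=O)c2ccc(Cl)nc21`, gives 7800 nM.
Compound 3, `C#CCn1cc(C(=O)NC(CC(=O)Nc2ccccn2)c2ccccc2)c(=O)c2cc(F)c(Cl)nc21`, gives > 10000 nM, again a limit of the assay and not a number.

These three compounds were tested in a functional assay on ECV-304 cells (Homo sapiens) for cytotoxicity, read by MTT assay, with a stated time of 72 h; on this read-out higher numbers stand for weaker inhibition and lower numbers for stronger inhibition. Compound 1 sits at a limit of the assay with > 10000 nM. Compound 2 gives 7800 nM. The change between them is cyclopentyl in place of pyridin-2-yl on an amide-type nitrogen, and it made an at least 1.2-fold lower number from compound 1 to compound 2 (0.10 log units; that floor lies within the scatter). Compound 3 also sits at a limit of the assay with > 10000 nM. Its core differs from the core of compound 1 by fluoro in place of hydrogen on an aromatic carbon, and the step is a step that the two limits leave unreadable from compound 1 to compound 3. Both limits rest on (the limit of > 10000 nM in this assay, at which 2 of the 3 values shown sit).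

Compound 4, `C#CCn1cc(C(=O)NC(CC(=O)NC2CCCC2)c2ccccc2)c(=O)c2cc(F)c(Cl)nc21`, is not yet measured. Among the measured compounds shown here, it carries the same change as the one from compound 1 to compound 2, namely (cyclopentyl in place of pyridin-2-yl on an amide-type nitrogen), made this time on the fluoro-bearing core of compound 3. Since the earlier step of this change, an at least 1.2-fold lower number from compound 1 to compound 2 (0.10 log units; that floor lies within the scatter), only reached the scatter from a limit, he expects at most a similar, modest step, an at least 1.1-fold lower number from compound 3 to compound 4 (0.07 log units; that floor lies within the scatter), in this assay. He estimates compound 4 at 8500 nM, with a plausible range from 4000 nM to 20000 nM, and accepts that the assay may again report only a limit for compound 4.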

Compound 4, half-maximal inhibitory concentration: 5100 nM
Beside the measured number, compound 4's estimate is 1.7-fold (0.22 log units) above it; measured number inside the range.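

In this assay the same change, cyclopentyl in place of pyridin-2-yl on an amide-type nitrogen, was carried onto the fluoro-bearing core and gave an at least 1.9-fold lower number from compound 3 to compound 4 (0.29 log units; that floor lies within the scatter) and, set beside the earlier step, it reads: the same change on two cores in this assay, an at least 1.2-fold lower number (0.10 log units; that floor lies within the scatter) from compound 1 to compound 2 and an at least 1.9-fold lower number (0.29 log units; that floor lies within the scatter) from compound 3 to compound 4; the limit leaves it open whether they differ. On both cores the cyclopentyl compound gives a readable number while the pyridin-2-yl compound stops at a limit of the assay, but this holds for these two pairs only, neither floor lies beyond the scatter, and the true size of either step stays hidden because of that limit: the limit of > 10000 nM in this assay, at which 2 of the 4 values shown sit. Between the two cyclopentyl compounds the fluoro group leaves a 1.5-fold lower number from compound 2 to compound 4 (0.18 log units; within the scatter) and so no difference that can be told apart, while the step between the two pyridin-2-yl compounds cannot be read.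

The compounds shown leave open whether another group on the same amide-type nitrogen, such as cyclohexyl or tert-butyl, would bring the number clearly below those of the cyclopentyl pair. They also leave open whether the change would carry over to a core with an amine in place of the chloro group.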